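The compounds below may be only part of what the source reports. "The series", "measured", "known", "first", "only" and "open" are said of these compounds alone.

Compound 1 `CCN(CC)Cc1ccc(Nc2nc3ccccc3n2Cc2ccc(F)cc2)cc1O`: 45800 nM
Compound 2 `CCN(CC)Cc1cc(F)cc(Nc2nc3ccccc3n2Cc2ccc(C(F)(F)F)cc2)c1O`: > 50000 nM
Compound 3 `Cc1cc(CNC(C)(C)C)c(O)c(Nc2nc3cc(F)c(F)cc3[nH]2)c1`: 16700 nM

In an ADME assay on CHO cells (Cricetulus griseus) for inhibition, read by MTT assay (on this read-out lower numbers stand for stronger inhibition and higher numbers for weaker inhibition), compound 1 gives 45800 nM and compound 3 gives 16700 nM. Among the compounds with values here, for compound 2 the assay reports no number but only a limit, > 50000 nM; it is the one value that sits at the limit of > 50000 nM in this assay, at which 1 of the 3 values shown sits. Compound 4 `CCN(CC)Cc1cc(Cl)cc(Nc2nc3ccccc3n2Cc2ccc(C(F)(F)F)cc2)c1O` differs from compound 2 in one place: chloro in place of fluoro on an aromatic carbon. Within the data shown here, no pair of measured compounds differs in a single place, so the size of such a swap in this assay is not known from these data. Compound 4 is expected to stay close to where compound 2 stands, with no step beyond the usual scatter. For compound 4 the estimate in this assay is 60000 nM, within 25000 nM to 150000 nM. This expectation amounts to a step that the limit leaves unreadable from compound 2 to compound 4.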

Compound 4, half-maximal inhibitory concentration: > 50000 nM
Compound 4 gave a limit, no number; the forecaster's own chance of this, stated with the estimate: 60%; the middle value does not contradict the limit.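

In this assay compound 4 gives only a limit, > 50000 nM. Within the data shown here, compound 2 also stands at a limit, so no step between compound 2 and compound 4 can be read. The compounds shown leave open how chloro and fluoro at this place compare in this assay.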